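Compound 3 to compound 4: a methyl group removed

The source may report more compounds than this note shows. Statements on the series, on what has been measured and on what is new or still open speak of the compounds shown alone.

In an ADME assay on Caco-2 cells (Homo sapiens) for permeability, in the apical to basolateral direction, at pH 7.4 (a lower number here means that the compound crosses the layer more slowly, a higher number that the compound crosses the layer faster), compound 1 (`Cc1ccc2[nH]c(C(=O)N[C@H]3CN(S(=O)(=O)c4ccccc4)C[C@@H]3C(=O)NC[C@H]3CCCN3)cc2c1`) gives 0.11 10^-6 cm/s, compound 2 (`Cc1ccc2[nH]c(C(=O)N[C@H]3CN(S(=O)(=O)c4ccccc4)C[C@@H]3C(=O)NC[C@@H]3CCCN3C)cc2c1`) gives 0.24 10^-6 cm/s and compound 3 (`Cc1ccc2[nH]c(C(=O)N[C@H]3CN(S(=O)(=O)c4ccccc4)C[C@@H]3C(=O)N[C@H]3CCCN(C)C3)cc2c1`) gives 0.3 10^-6 cm/s. Compound 3 cannot be separated from compound 2, with a 1.3-fold higher number from compound 2 to compound 3 (0.10 log units; within the scatter), but it stands clear of compound 1, with a 2.7-fold higher number from compound 1 to compound 3 (0.44 log units; beyond the scatter).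

Compound 4 (`Cc1ccc2[nH]c(C(=O)N[C@H]3CN(S(=O)(=O)c4ccccc4)C[C@@H]3C(=O)N[C@@H]3CCCNC3)cc2c1`) is unmeasured and differs from compound 3 by piperidin-3-yl in place of 1-methylpiperidin-3-yl on an amide-type nitrogen. Among the compounds with values here, the closest precedent is the pair that differs by 1-methylpyrrolidin-2-yl in place of pyrrolidin-2-yl, with a 2.2-fold higher number from compound 1 to compound 2 (0.34 log units; beyond the scatter). Read in reverse, this modest step points to a lower number when the methyl is absent. The step from compound 1 to compound 3 also changes the ring, so it bears less directly.

The expected change is a 2.1-fold lower number from compound 3 to compound 4 (0.33 log units; beyond the scatter), a modest fall of similar size. Compound 4 is estimated at 0.14 10^-6 cm/s, with an expected range of 0.07 10^-6 cm/s to 0.28 10^-6 cm/s.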

Compound 4, apparent permeability: 0.04 10^-6 cm/s
Estimate against measurement, compound 4: 3.5-fold (0.54 log units) above; the measured number lies below the stated range.
By their numbers in this assay, from the lowest: compound 4; then compound 1; then compounds 2 and 3 (each within the scatter of the next).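

Removing the methyl from 1-methylpiperidin-3-yl on the amide-type nitrogen has a larger effect on the number in this assay (a 7.5-fold lower number from compound 3 to compound 4 (0.88 log units; beyond the scatter)) than the methyl step in the pyrrolidine pair (a 2.2-fold higher number from compound 1 to compound 2 (0.34 log units; beyond the scatter)), so the size of this step does not carry over from one amine substituent to the other. Compounds 2 and 3, both with a methyl on the ring nitrogen, lie within the scatter of each other, but piperidin-3-yl separates clearly from (1-methylpyrrolidin-2-yl)methyl (a 6.0-fold lower number from compound 2 to compound 4 (0.78 log units; beyond the scatter)) and from the unmethylated (pyrrolidin-2-yl)methyl (a 2.8-fold lower number from compound 1 to compound 4 (0.44 log units; beyond the scatter)). No measurement at hand explains the fall.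

The compounds shown leave open whether an ethyl or an acetyl on the ring nitrogen of piperidin-3-yl would restore the number seen with methyl. They also leave open how (piperidin-3-yl)methyl would stand, which would separate the ring from the chain.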